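The source may report more compounds than this note shows. Statements on the series, on what has been measured and on what is new or still open speak of the compounds shown alone.

Compound 1 `COc1cc(C(=O)c2sc(-c3ccc(Cl)cc3)cc2N)cc(OC)c1OC`: 90 nM
Compound 2 `COc1cc(C(=O)c2sc(-c3ccsc3)cc2N)cc(OC)c1OC`: 3.7 nM

In a functional assay on FM3A cells (Mus musculus) for antiproliferative activity (on this read-out higher numbers stand for weaker inhibition and lower numbers for stronger inhibition), compound 2 holds the lower of the two numbers, at 3.7 nM. Compound 3 `COc1ccc(-c2cc(N)c(C(=O)c3cc(OC)c(OC)c(OC)c3)s2)cc1` has 4-methoxyphenyl in place of thiophen-3-yl on an aromatic carbon. For the measured compounds named here, one measured step bears on this change, the large 24-fold lower number from compound 1 to compound 2 (1.39 log units; beyond the scatter), where thiophen-3-yl replaced 4-chlorophenyl. Compound 3 again carries a six-membered aromatic ring of carbon only there, like compound 1 at 90 nM, so a rise beyond the scatter is expected in this assay, probably smaller than that step. The expected change is a 6.8-fold higher number from compound 2 to compound 3 (0.83 log units; beyond the scatter). For compound 3 the estimate is 25 nM, with an expected range of 6 nM to 100 nM.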

Compound 3, half-maximal inhibitory concentration: 31 nM
Estimate against measurement, compound 3: 1.2-fold (0.09 log units) below, within the range that was stated.
By their numbers in this assay, from the lowest: compound 2; then compound 3; then compound 1.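

In this assay, 4-methoxyphenyl in place of thiophen-3-yl next to the ring sulfur gives an 8.4-fold higher number from compound 2 to compound 3 (0.92 log units; beyond the scatter) and so places thiophen-3-yl ahead of both six-membered aromatic rings of carbon only shown here. The group on that ring also counts, since methoxy in place of chloro gives a 2.9-fold lower number from compound 1 to compound 3 (0.46 log units; beyond the scatter) while the rest of the compound stays the same. On these data alone, whether a furan-3-yl, thiophen-2-yl or pyridin-3-yl group would match thiophen-3-yl at this position remains open. Nothing available gives a reason for either step.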